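Working notes: distal aryl change toward compound 4

This account rests on a few compounds, and the source may have more. Where it says the series, first, only, none or still open, it means among the compounds named here.

Measured so far in an assay on HEK293 cells for positive allosteric modulation of metabotropic glutamate receptor 2 (Rattus norvegicus), read by thallium flux, with a stated time of 2.5 min; a higher number here means a larger maximal response, a lower number a smaller maximal response:
compound 1, `Cc1c(OCCCCOc2ccc(C(=O)O)cc2)ccc(C(=O)CC2CCCC2)c1O`, gives 82.6%
compound 2, `Cc1c(OCCCCOc2ccc(C(=O)O)cc2)ccc(C(=O)CC2CCCC2)c1C`, gives 16.2%
compound 3, `Cc1c(OCCCCOc2ccc(C(=O)O)cc2)ccc(C(=O)CC(C)C)c1O`, gives 88%

Compound 1 stands second of the three numbers in this assay. Its nearest neighbour is compound 3, reached by a number 5.4 percentage points higher from compound 1 to compound 3 (within the scatter), a step within the scatter. Its furthest neighbour is compound 2, reached by a number 66.4 percentage points lower from compound 1 to compound 2 (beyond the scatter), a step beyond the scatter.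

Compound 4, `Cc1ccc(C(=O)O)cc1OCCCCOc1ccc(C(=O)CC2CCCC2)c(O)c1C`, is not yet measured. It differs from compound 1 as follows: 5-carboxy-2-methylphenyl in place of 4-carboxyphenyl on an oxygen on a saturated carbon.

Neither measured step touches this part of the molecule: the step from compound 1 to compound 2 alters the hydroxy on the central aromatic ring, and the step from compound 1 to compound 3 alters the saturated chain carbon bound to the carbonyl. Among the compounds with values here, the data hold no step on the 4-carboxyphenyl end of the chain, so no measured step bears directly on the change to compound 4. The change leaves the carboxylic acid in place and adds one methyl while shifting the carboxy, a modest alteration far from the two positions already probed. The expectation is therefore a step of a number 7.6 percentage points lower from compound 1 to compound 4 (within the scatter), no change beyond the scatter, held with low confidence. Compound 4 is estimated at 75%, with a range from 40% to 100%.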

Compound 4, largest response reached (reported as percent of maximum), in percent of the reference or control that the assay uses: 67.5%
Estimate against measurement, compound 4: 7.5 percentage points above, within the range that was stated.
By their numbers in this assay, from the lowest: compound 2; then compound 4; then compounds 1 and 3 (each within the scatter of the next).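

Within the data shown here, the distal aryl end of the chain is not silent in this assay: 5-carboxy-2-methylphenyl in place of 4-carboxyphenyl, on an oxygen on a saturated carbon, gives a number 15.1 percentage points lower from compound 1 to compound 4 (beyond the scatter) and is the first step at this end. The response is reduced but not lost, with compound 4 at 67.5%, and this step is smaller than a number 66.4 percentage points lower from compound 1 to compound 2 (beyond the scatter), the change of hydroxy to methyl on the aromatic carbon, so the aryl end shows a real but lesser dependence on structure in the compounds at hand. Among these compounds, no measurement on these compounds accounts for the step, and the single change combines an added methyl with a shifted carboxy, so its size cannot be assigned to either part.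

Going by these compounds, whether the methyl, the shift of the carboxy or both together produce the step remains open, as does the outcome with an ethyl or a methoxy in place of that methyl. Also open, on these data alone, is how a tetrazole in place of the carboxylic acid, or a longer chain to the aryl oxygen, would behave at this end of the molecule.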